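A few compounds are considered here, and "the series" means these few. Any claim that something is new, unique, unknown or untested is made for them only; others in the source may bear on it.

Measured so far:
compound 1 `Cc1ccc([C@H](C)NC(=O)Cn2nnc3ccccc3c2=O)cc1` — in an ADME assay on microsomes from liver (Homo sapiens) for metabolic stability (on this read-out higher numbers stand for fast clearance and lower numbers for slow clearance), compound 1 gives < 9.9 mL/min/kg
compound 2 `C[C@H](NC(=O)Cn1nnc2ccccc2c1=O)c1ccc(F)cc1` — in this assay compound 2 gives 31 mL/min/kg

The value of compound 1 is a limit of the assay, not a number (the limit of < 9.9 mL/min/kg in this assay, at which 1 of the 2 values shown sits). Among the measured compounds shown here, the single measured step, an at least 3.1-fold higher number from compound 1 to compound 2 (0.49 log units; beyond the scatter), alters a different part of the shared core and does not bear on the present change. Compound 3 `Cc1ccc([C@@H](NC(=O)Cn2nnc3ccccc3c2=O)C(C)C)cc1` differs from compound 1 in isopropyl in place of methyl on a saturated chain carbon bound to an amide-type nitrogen and an aromatic carbon. For the measured compounds named here, with no measured step covering this change, the expectation for compound 3 rests on compound 1 alone, and the step of an at least 1.2-fold higher number from compound 1 to compound 3 (0.08 log units; that floor lies within the scatter) is expected to stay within the scatter. Compound 3 is estimated at 12 mL/min/kg, within 5 mL/min/kg to 30 mL/min/kg.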

Compound 3, clearance: 34 mL/min/kg
Estimate against measurement, compound 3: 2.8-fold (0.45 log units) below; the whole stated range lies below it.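

In this assay, isopropyl in place of methyl on a saturated chain carbon bound to an amide-type nitrogen and an aromatic carbon gives an at least 3.4-fold higher number from compound 1 to compound 3 (0.53 log units; beyond the scatter). The read-out therefore responds to a change at this carbon as well as to the earlier change on the aromatic carbon. The true size of the step stays unknown, as compound 1 stands at a limit of the assay: the limit of < 9.9 mL/min/kg in this assay, at which 1 of the 3 values shown sits.

Going by these compounds, what ethyl, cyclopropyl or an amine would give on this carbon remains open. So does whether isopropyl here and fluoro on the aromatic carbon would add up in one compound.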